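The source may report more compounds than this note shows. Statements on the series, on what has been measured and on what is new or still open speak of the compounds shown alone.

In a functional assay on NPC-TW01 cells (Homo sapiens) for antiproliferative activity, read by MTT assay, with a stated time of 72 h (a lower number here means a stronger inhibitor of growth, a higher number a weaker inhibitor of growth), the measured compounds read as follows:

compound 1, `O=C(COc1ccc2oc(-c3ccccc3)cc(=O)c2c1)Nc1ccc2ccccc2c1`: 6750 nM
compound 2, `O=C(COc1ccc2c(=O)c(-c3ccccc3)coc2c1)Nc1ccc2ccccc2c1`: 1370 nM
compound 3, `O=C(COc1c(-c2ccccc2)oc2ccccc2c1=O)Nc1ccccc1`: > 10000 nM

For compound 3 the entry is a limit of the assay rather than a number; it is the only one of the three that sits at the limit of > 10000 nM in this assay, at which 1 of the 3 values shown sits. As far as these compounds go, compound 3 therefore stands at the weak end of what this assay can report, and how much weaker it really is remains unknown.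

Compound 4, `COc1ccc(NC(=O)COc2c(-c3ccccc3)oc3ccccc3c2=O)cc1`, is the next compound in this series. It differs from compound 3 in one place: methoxy in place of hydrogen on an aromatic carbon. Within the data shown here, no pair of measured compounds shows this particular change, so there is no measured step to lean on, and the change is small. With compound 3 already at the limit, no movement beyond the usual scatter is expected; the step from compound 3 to compound 4 in this assay is estimated as a step that the limit leaves unreadable from compound 3 to compound 4. Compound 4 is expected to come out near 12000 nM, with a plausible range from 4000 nM to 30000 nM, and it may well return only a limit again.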

Compound 4, concentration for 50% growth inhibition: 5480 nM
Compound 4: middle estimate off by 2.2-fold (0.34 log units), on the high side, and the stated range covers the measured number.
By their numbers in this assay, from the lowest: compound 2; then compounds 4 and 1 (each within the scatter of the next). At a limit, above all of these: compound 3.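

Where compound 3 has a phenyl, compound 4 carries a 4-methoxyphenyl group, and in this assay compound 4 gives 5480 nM, a measured number rather than a limit. Methoxy in place of hydrogen at this place, para to a large group, gives an at least 1.8-fold lower number from compound 3 to compound 4 (0.26 log units; that floor lies within the scatter), so this is a hint that the ring position can respond to a change, but the floor alone does not establish a real gain. Compound 3 is reported only as a limit, so the full size of the step cannot be read: the limit of > 10000 nM in this assay, at which 1 of the 4 values shown sits.

As far as these compounds go, whether an amine, a carboxylic acid or a longer chain such as ethoxy at this place would lower the number further remains open. The compounds shown also do not tell whether adding methoxy would have a similar effect on compound 1 or compound 2.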